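The source may hold more compounds than are shown below. What is called first, only, known or untested is meant among the compounds shown, and "the series" means these compounds.

Values in a functional assay on HCT-116 cells (Homo sapiens) for antiproliferative activity, read by luminescence, with a stated time of 72 h; a higher number here means a weaker inhibitor, a lower number a stronger inhibitor:
- compound 1 `CN1CC2(CC(=O)c3cc(/C=C/C(=O)NO)ccc3O2)C1`: 178 nM
- compound 2 `CC(=O)N1CC2(CC(=O)c3cc(/C=C/C(=O)NO)ccc3O2)C1`: 10500 nM
- compound 3 `CCOC(=O)N1CC2(CC(=O)c3cc(/C=C/C(=O)NO)ccc3O2)C1`: not yet measured

Compound 1 has the lower of the two numbers in this assay. Compound 3 differs from it as follows: ethoxycarbonyl in place of methyl on an amine nitrogen in a ring. In words, this is ethoxycarbonyl in place of methyl on an amine nitrogen in a ring. Going by the values given here, the one measured step that bears on this is for acetyl in place of methyl on an amine nitrogen in a ring: a 59-fold higher number from compound 1 to compound 2 (1.77 log units; beyond the scatter), large and beyond the scatter. A large step towards a higher number is therefore expected, though perhaps a somewhat smaller one. The estimated step is a 22-fold higher number from compound 1 to compound 3 (1.35 log units; beyond the scatter). For compound 3 the expected value is 4000 nM, with an estimated range of 1000 nM to 15000 nM.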

Compound 3, half-maximal inhibitory concentration: 1230 nM
Beside the measured number, compound 3's estimate is 3.3-fold (0.51 log units) above it, and the stated range covers the measured number.
By their numbers in this assay, from the lowest: compound 1; then compound 3; then compound 2.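

In this assay, ethoxycarbonyl on the amine nitrogen in the ring still gives a weaker result than methyl, with a 6.9-fold higher number from compound 1 to compound 3 (0.84 log units; beyond the scatter) as the step, so a second carbonyl-bearing group also moves away from compound 1. The two such groups are not equivalent: ethoxy in place of methyl on the carbonyl carbon gives an 8.5-fold lower number from compound 2 to compound 3 (0.93 log units; beyond the scatter) in the same assay. Part of the loss seen with acetyl is therefore recovered, though not all of it.

Nothing given here explains these differences.

On these data alone, whether a free ring amine, an ethyl group or a benzyl group on this nitrogen would match methyl remains open.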